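Methyl for hydroxy on the pendant phenyl ring

The compounds below may be only part of what the source reports. "The series", "measured", "known", "first", "only" and "open" are said of these compounds alone.

Compound 2 `O=c1cc(CNCc2cccc(O)c2)oc2ccc(O)c(O)c12` in an ADME assay on Huh-7 cells (Homo sapiens) for cytotoxicity (a higher number here means that more compound is tolerated, a lower number that less compound is tolerated), gives > 100000 nM, a limit of the assay (the limit of > 100000 nM in this assay, at which 1 of the 2 values shown sits). Compound 1 `Cc1ccccc1CNCc1cc(=O)c2c(O)c(O)ccc2o1` gives 52200 nM in this assay. Among the measured compounds shown here, the only measured step, an at least 1.9-fold higher number from compound 1 to compound 2 (0.28 log units; that floor lies within the scatter), reaches that limit, so its size is open. For the measured compounds named here, compound 3 `Cc1cccc(CNCc2cc(=O)c3c(O)c(O)ccc3o2)c1` differs from compound 2 by methyl in place of hydroxy on an aromatic carbon; no measured step covers this exchange, and with compound 2 known only as a limit no direction beyond the scatter is expected. Compound 3 is estimated at 70000 nM, within 30000 nM to 160000 nM. The expected step from compound 2 is an at least 1.4-fold lower number from compound 2 to compound 3 (0.15 log units; that floor lies within the scatter).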

Compound 3, half-maximal cytotoxic concentration: > 100000 nM
Compound 3: no number, only a limit (the forecaster's own chance of this, stated with the estimate: 40%); middle value at least 1.4-fold (0.15 log units) away from the limit.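

In this assay, among the compounds shown here, compound 3 sits at a limit, as compound 2 does, so the step between them cannot be read: the limit of > 100000 nM in this assay, at which 2 of the 3 values shown sit. The 3-hydroxyphenyl group is therefore not the only group at this place to reach that limit, since 3-methylphenyl reaches it too. From the compounds shown here alone, exchanging 2-methylphenyl for 3-methylphenyl gives an at least 1.9-fold higher number from compound 1 to compound 3 (0.28 log units; that floor lies within the scatter), so the size of that change also stays open. Going by these compounds, what number compound 2 and compound 3 would give beyond the limit remains unknown, as does how a methoxy group or a chlorine atom would fare at this place.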